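A few compounds are considered here, and "the series" means these few. Any claim that something is new, unique, unknown or untested is made for them only; others in the source may bear on it.

In a functional assay on BV-2 cells (Mus musculus) for inhibition, read by Griess assay, with a stated time of 24 h (on this read-out lower numbers stand for stronger inhibition and higher numbers for weaker inhibition), compound 1 (`C=CCn1ccc(-c2cc(Br)ccc2O)n1`) gives 112000 nM. Within the data shown here, compound 2 (`C=CCc1ccc(O)c(-c2ccn(CC=C)n2)c1`) gives 1200 nM, the lowest of the two numbers so far. Compound 3 (`C=CCn1ccc(-c2cc(C=C)ccc2O)n1`) has vinyl in place of allyl on an aromatic carbon, para to a hydroxy group: vinyl in place of allyl on an aromatic carbon. Among the measured compounds shown here, only one measured step bears on this place. It is the large step of a 93-fold lower number from compound 1 to compound 2 (1.97 log units; beyond the scatter), which came with allyl in place of bromo on the same aromatic carbon. For the measured compounds named here, that step shows that the group here can matter a great deal, but no vinyl compound has been measured, so it gives no direct size for the new change. Vinyl resembles allyl in having a double bond outside aromatic rings, so a much smaller, upward step is expected, towards weaker inhibition. The expected change is a 2.1-fold higher number from compound 2 to compound 3 (0.32 log units; beyond the scatter). For compound 3, the estimate is 2500 nM, within an expected range of 700 nM to 15000 nM.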

Compound 3, half-maximal inhibitory concentration: 30500 nM
Compound 3: middle estimate off by 12-fold (1.09 log units), on the low side; measured number above the stated range.
By their numbers in this assay, from the lowest: compound 2; then compound 3; then compound 1.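

At this position, allyl and vinyl are far from interchangeable, even though each has a double bond outside aromatic rings: vinyl in place of allyl gives a 25-fold higher number from compound 2 to compound 3 (1.41 log units; beyond the scatter) and so much weaker inhibition. Vinyl in place of bromo gives only a 3.7-fold lower number from compound 1 to compound 3 (0.56 log units; beyond the scatter) and so a modest gain. Having that double bond on the aromatic carbon therefore does not by itself give the strong inhibition of compound 2, and allyl, with 3 heavy atoms against 2 for vinyl, stands well apart from both other groups.

Nothing measured here explains why allyl and vinyl differ so much. On these data alone, it remains open whether a propyl group, which has the length of allyl without its double bond, or a longer chain such as butyl would keep the inhibition of compound 2.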